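Working notes: chloro added to compound 2

This account rests on a few compounds, and the source may have more. Where it says the series, first, only, none or still open, it means among the compounds named here.

Measured in a functional assay on MDA-MB-231 cells (Homo sapiens) for cytotoxicity, read by MTT assay, with a stated time of 48 h; on this read-out lower numbers stand for stronger inhibition and higher numbers for weaker inhibition:
- compound 1 `CCn1c(/C=C2/C(=O)Nc3ccccc32)nc2ccccc21`: > 50000 nM, a limit of the assay and not a number
- compound 2 `CC(C)n1c(/C=C2/C(=O)Nc3ccccc32)nc2ccccc21`: 30400 nM

Among the compounds with values here, compound 2 at 30400 nM holds the only actual number. Compound 1 sits at a limit, (the limit of > 50000 nM in this assay, at which 1 of the 2 values shown sits). Within the data shown here, the one measured step is an at least 1.6-fold lower number from compound 1 to compound 2 (0.21 log units; that floor lies within the scatter). It lies on a saturated chain, so it offers little guidance for a change on an aromatic carbon.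

Compound 3 `CC(C)n1c(/C=C2/C(=O)Nc3ccc(Cl)cc32)nc2ccccc21` carries chloro in place of hydrogen on an aromatic carbon. Among the measured compounds shown here, no measured step covers this place, so the data fix neither size nor direction. Compound 2 stands at 30400 nM in this assay, and only a modest shift from it is expected, leaning slightly toward stronger inhibition. The estimated change is a 1.5-fold lower number from compound 2 to compound 3 (0.18 log units; within the scatter). Compound 3 is expected at 20000 nM, with an estimated range of 7000 nM to 50000 nM.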

Compound 3, half-maximal inhibitory concentration: 25100 nM
The estimate for compound 3 lay 1.3-fold (0.10 log units) below the measured number; the range from low to high includes it.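

In this assay, within the data shown here, the first reading at this position, on an aromatic carbon meta to a fused ring and para to a fused ring, is a 1.2-fold lower number from compound 2 to compound 3 (0.08 log units; within the scatter) and so the entry of chloro for hydrogen does not move the number beyond the scatter. A single added chlorine atom is thus tolerated here, and compound 3 still gives a real number rather than an assay limit, but this one step sets no direction for the position. Nothing in the data at hand gives a reason for this result.

Going by these compounds, whether a different group on this carbon, such as methoxy, nitrile or an amine, would shift the number beyond the scatter remains open. Also open, on these data alone, is how chloro would read on other aromatic carbons of the shared core.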